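Fluoropiperidine for dihydropyrrole on the nitrile-bearing core

The source may report more compounds than this note shows. Statements on the series, on what has been measured and on what is new or still open speak of the compounds shown alone.

Compound 1 `Nc1nc(-c2ccco2)nc2sc(CN3CCC(F)CC3)cc12` in a functional assay on the whole organism (strain balb/c) with Mus musculus as the target, with a stated time of 30 min (on this read-out higher numbers stand for an effect only at larger amounts of compound and lower numbers for an effect already at smaller amounts), gives < 1 mg/kg, which is a limit of the assay and not a number.
Compound 2 `Nc1nc(-c2ccco2)nc2sc(CN3CC=CC3)cc12` in this assay gives < 0.1 mg/kg, again a limit rather than a number.
Compound 3 `N#Cc1cccc(-c2nc(N)c3cc(CN4CC=CC4)sc3n2)c1` in this assay gives "not determined" (no result reported), so no result exists for it there.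

Compound 3 therefore stands nowhere on the numbers shown: of the three values, one sits at the limit of < 0.1 mg/kg in this assay, at which 1 of the 3 values shown sits, one at the limit of < 1 mg/kg in this assay, at which 1 of the 3 values shown sits, and its own is missing. The unmeasured compound 4 `N#Cc1cccc(-c2nc(N)c3cc(CN4CCC(F)CC4)sc3n2)c1` differs from compound 3 by a group of 7 heavy atoms (5 carbon, 1 nitrogen, 1 fluorine; one six-membered non-aromatic ring with 1 hetero atom) in place of a group of 5 heavy atoms (4 carbon, 1 nitrogen; one five-membered non-aromatic ring with 1 hetero atom), on a saturated chain carbon bound to an aromatic carbon.

Among the compounds with values here, only one measured step bears on this exchange, a step that the two limits leave unreadable from compound 1 to compound 2, which carries the same pair of groups in the opposite direction on the other core; since both ends are limits, its size is not readable, and it gives no direction for the step in this assay. What remains is that compound 1 carries the 4-fluoropiperidin-1-yl group and sits at the limit of < 1 mg/kg in this assay, at which 1 of the 3 values shown sits, which serves as the anchor.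

Compound 4 is therefore expected in this assay at about 0.5 mg/kg, with a range from 0.05 mg/kg to 3 mg/kg, and with a sizeable chance that the assay again reports only a limit.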

Compound 4, dose for half-maximal effect: < 1 mg/kg
Compound 4 gave a limit, no number; the forecaster's own chance of this, stated with the estimate: 60%; the middle value lies beyond the limit too.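

In this assay compound 1 and compound 4 each give only a limit, not a number, so no new step can be read from compound 4, including the exchange of furan-2-yl for 3-cyanophenyl. The compounds shown leave open whether, and how far, either 3-cyanophenyl or 4-fluoropiperidin-1-yl shifts the dose for half-maximal effect.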